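A few compounds are considered here, and "the series" means these few. Any claim that something is new, unique, unknown or untested is made for them only; others in the source may bear on it.

Measured so far in a functional assay on WiDr cells (Homo sapiens) for antiproliferative activity, read by sulforhodamine B assay, with a stated time of 48 h; a higher number here means a weaker inhibitor of growth, a lower number a stronger inhibitor of growth
compound 1 `CC(C)(C)[Si](C)(C)O[C@@H]1CCCO[C@@H]1CO` gives > 100000 nM
compound 2 `CC(C)(C)[Si](C)(C)O[C@@H]1CCCO[C@@H]1/C=C/C(=O)OCc1ccccc1` gives 90000 nM

Compound 1 stands at > 100000 nM in this assay as a limit of the assay and not a number. Among the measured compounds shown here, compound 2 gives 90000 nM as a number, and no step between the two can be read from these values.

The step followed here goes to compound 3 `COC(=O)/C=C/[C@H]1OCCC[C@H]1O[Si](C)(C)C(C)(C)C` with the change 2-(methoxycarbonyl)ethenyl in place of hydroxymethyl on a saturated ring carbon on the shared core: 2-(methoxycarbonyl)ethenyl in place of hydroxymethyl on a saturated ring carbon, next to the ring oxygen. For the measured compounds named here, no measured step exists for this change, so its size in this assay can only be estimated. Little movement beyond the scatter is expected, and any shift should be towards stronger inhibition of growth. Going by the values given here, the only numeric anchor is compound 2 at 90000 nM and the expectation leans on it. The expected step is an at least 1.0-fold lower number from compound 1 to compound 3 (0.02 log units; that floor lies within the scatter) and another report of a limit would be no surprise. In this assay the estimated value for compound 3 is 95000 nM within an expected range of 45000 nM to 150000 nM (both ends estimated).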

Compound 3, concentration for 50% growth inhibition: > 100000 nM
Compound 3: only a limit was reported; the forecaster's own chance of this, stated with the estimate: 55%; at least 1.0-fold (0.02 log units) between middle value and limit.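

In this assay compound 3 gives > 100000 nM, which is a limit of the assay and not a number. With 2-(methoxycarbonyl)ethenyl in place of hydroxymethyl on a saturated ring carbon, the series still shows no measured growth inhibition at this position, and the step between compound 1 and compound 3 cannot be read, as both values are limits. Hydrogen in place of phenyl on a saturated chain carbon bound to an oxygen next to a carbonyl group gives an at least 1.1-fold higher number from compound 2 to compound 3 (0.04 log units; that floor lies within the scatter), so the compounds shown give no firm sign that the phenyl group matters in this series.

On these data alone, how far any change at this position moves growth inhibition stays open, with the values shown crowded at the top of the readable range: the limit of > 100000 nM in this assay, at which 2 of the 3 values shown sit. As far as these compounds go, whether an amine or a carboxylic acid at the end of the side chain, or a longer chain on the same ring carbon, would give a clearly readable number in this assay also remains open.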